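The source may hold more compounds than are shown below. What is called first, only, known or untested is meant among the compounds shown, and "the series" means these compounds.

In an in vitro functional assay on cells for agonist activity at Bombesin receptor subtype-3 (Homo sapiens), read by luminescence and calcium flux (a lower number here means that less compound is needed, a higher number that more compound is needed for the effect), the three measured compounds gave the following numbers:

Compound 1, `CCCCc1cnc(C(CCCC)Cc2ccc(-c3ccccc3C(=O)O)cc2)[nH]1`: 2660 nM
Compound 2, `O=C(O)c1ccccc1-c1ccc(CCc2ncc(CC3CCC3)[nH]2)cc1`: 588 nM
Compound 3, `O=C(O)c1ccccc1-c1ccc(CCc2ncc(CC3CCCCCC3)[nH]2)cc1`: 88 nM

Compound 1 stands highest of the three in this assay; compound 2 is nearest to it, and compound 3 is furthest, both lower by margins beyond the scatter. Compound 4, `CCCCc1cnc(C(Cc2ccc(-c3ccccc3C(=O)O)cc2)C(C)C)[nH]1`, is not yet measured. It differs from compound 1 in one place: isopropyl in place of butyl on a saturated chain carbon bound to an aromatic carbon and a saturated chain carbon.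

For the measured compounds named here, only one measured step is available for comparison: a 6.7-fold lower number from compound 2 to compound 3 (0.82 log units; beyond the scatter). That step concerns a ring on a saturated chain carbon bound to an aromatic carbon, whereas the change from compound 1 to compound 4 swaps one short acyclic chain for another at a different saturated chain carbon. Going by the values given here, the measured step therefore bears only loosely on the present change, and no measured pair shows what the butyl group itself contributes. With a difference of a single carbon and no ring involved, compound 4 is expected to stay close to compound 1, with an estimated step of a 1.1-fold higher number from compound 1 to compound 4 (0.05 log units; within the scatter), which is within the scatter. The estimate for compound 4 in this assay is 3000 nM, in a range from 1200 nM to 8000 nM.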

Compound 4, half-maximal effective concentration: 4620 nM
Compound 4: middle estimate off by 1.5-fold (0.19 log units), on the low side, within the range that was stated.
By their numbers in this assay, from the lowest: compound 3; then compound 2; then compounds 1 and 4 (each within the scatter of the next).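

In this assay, for the compounds shown here, the step of a 1.7-fold higher number from compound 1 to compound 4 (0.24 log units; within the scatter) is the first measured change at this saturated chain carbon, bound to an aromatic carbon and a saturated chain carbon, and it lies within the scatter, so compound 1 and compound 4 cannot be told apart here. Going by these compounds alone, this place therefore accepts isopropyl in place of butyl without a change that can be read, whereas the only earlier one-place step, a 6.7-fold lower number from compound 2 to compound 3 (0.82 log units; beyond the scatter), concerned a ring at another place and went beyond the scatter. Nothing at hand accounts for this outcome.

Within the data shown here, the two compounds show only two acyclic carbon groups at this place, so it remains open whether a hydrogen, a longer chain such as hexyl, a cyclohexyl ring, a hydroxyl or an amine there would shift the number beyond the scatter. Also open, on these data alone, is whether the cycloheptyl group of compound 3, which gives 88 nM, would carry the same step when combined with a butyl or isopropyl group at this place.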